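A few compounds are considered here, and "the series" means these few. Any claim that something is new, unique, unknown or untested is made for them only; others in the source may bear on it.

Series notes, measured in a physicochemical assay for lipophilicity, at pH 7.4; a higher number here means a more lipophilic compound, a lower number a more polar compound:
- compound 1 `Cc1cc(C(=O)Nc2ccccc2)nn1Cc1cc(Cl)ccc1OCc1ccccc1`: > 3.7 (a limit)
- compound 2 `Cc1cc(C(=O)Nc2c(F)cccc2F)nn1Cc1cc(Cl)ccc1OCc1ccccc1`: 3.7
- compound 3 `COC(=O)Nc1cc(C)n(Cc2cc(Cl)ccc2OCc2ccccc2)n1`: > 3.7 (a limit)

Compound 3 stands at > 3.7, which is a limit and not a number. The set crowds at one end: the limit of > 3.7 in this assay, at which 2 of the 3 values shown sit. Among the measured compounds shown here, compound 2 holds the only number, 3.7.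

The next compound is compound 4 `Cc1cc(NC(=O)O[C@H]2CCOC2)nn1Cc1cc(Cl)ccc1OCc1ccccc1`. The change is oxolan-3-yl in place of methyl on an oxygen next to a carbonyl group.

For the measured compounds named here, no measured step makes this change. The closest are a step that the two limits leave unreadable from compound 1 to compound 3 and a number no lower from compound 2 to compound 3 (the limit leaves the size open), and neither has a readable size. a number no higher from compound 1 to compound 2 (the limit leaves the size open) lies elsewhere in the molecule and gives no size either. The expectation therefore rests on compound 2 at 3.7 as the only numerical anchor, and it stays loose. A small fall is expected, as a number at least 0.10 log units lower from compound 3 to compound 4 (that floor lies within the scatter) in this assay, though that estimate is uncertain in size. The estimated value for compound 4 is 3.6, with an expected range of 3.2 to 4.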

Compound 4, distribution coefficient: 2.7
The estimate for compound 4 lay 0.90 log units above the measured number, outside the stated range (below it).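

In this assay, among the compounds shown here, oxolan-3-yl in place of methyl on an oxygen next to a carbonyl group gives the first step at this position with a readable lower bound: a number at least 1.00 log units lower from compound 3 to compound 4 (beyond the scatter). Compound 4 also opens the first measured gap in the set, with a number 1.00 log units lower from compound 2 to compound 4 (beyond the scatter) and a number at least 1.00 log units lower from compound 1 to compound 4 (beyond the scatter). The earlier steps among compound 1, compound 2 and compound 3 cannot be read, and two of the three new steps give only a floor, because of where the values crowd: the limit of > 3.7 in this assay, at which 2 of the 4 values shown sit.

On these data alone, it remains open whether the step follows the ring oxygen or the ring carbons of oxolan-3-yl; a cyclopentyl or an ethyl group on the same oxygen would separate the two. As far as these compounds go, how the opposite configuration at the defined stereocentre would read also stays open.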